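This account rests on a few compounds, and the source may have more. Where it says the series, first, only, none or still open, it means among the compounds named here.

Compound 1, `CSc1[nH]ccc2ncnc1-2`: < 5%
Compound 2, `OC[C@H]1OC(n2cnc3c(Nc4ccccc4)nccc32)[C@H](O)[C@@H]1O`: 10%
Compound 3, `OC[C@H]1O[C@@H](n2cnc3c(NCc4ccccc4)nccc32)C[C@@H]1O`: 8%

Three compounds have been run in a functional assay on EL4 cells (Mus musculus) for inhibition, tested at 100 uM; a higher number here means more inhibition at the concentration tested (going by the name of the read-out), a lower number less inhibition. Compound 1 gives only a limit there, < 5%, and so contributes no number. Compound 2 reaches 10% in this assay. Compound 3 gives 8% in this assay; of the two numbers reported this is the lower one, yet the gap to compound 2 falls within the usual scatter of repeated measurements, so the two cannot be told apart. The account notes (the limit of < 5% in this assay, at which 1 of the 3 values shown sits).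

Compound 4, `CN(C)c1nccc2c1ncn2[C@H]1C[C@H](O)[C@@H](CO)O1`, has not been measured. It differs from compound 3 in one place: dimethylamino in place of benzylamino on an aromatic carbon. Going by the values given here, no step between two measured compounds has been charted, so the effect of this change is not known from the data. Among the compounds with values here, with compound 3 at 8% and compound 2 at 10%, both small, the room for a large downward step is limited, and nothing among the measured compounds points to a rise. The step from compound 3 to compound 4 is therefore expected to be small, a number 3 percentage points lower from compound 3 to compound 4 (within the scatter), within the scatter or slightly downward, with a real chance that only a limit is reported. Compound 4 is estimated at 5% in this assay, between 0% and 14%.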

Compound 4, a percentage reported as inhibition, at one concentration (the size of the read-out at that concentration, not a potency): < 5%
Compound 4: no number, only a limit; the forecaster's own chance of this, stated with the estimate: 40%; the middle value sits exactly at the limit.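

In this assay, going by these compounds alone, dimethylamino in place of benzylamino on an aromatic carbon, next to the ring nitrogen, gives a number at least 3 percentage points lower from compound 3 to compound 4 (that floor lies within the scatter), the first change at this position that can be read between two measured compounds. The step is only a floor, and since that floor lies within the scatter, it does not establish a real loss, although it does show that the smaller group with no ring and no hydrogen-bond donor brings no measurable gain in inhibition at the concentration tested. With this result, the position has carried two different amino groups without the read-out leaving the bottom of its range, and the values there increasingly reach the limit of the assay: the limit of < 5% in this assay, at which 2 of the 4 values shown sit.

From the compounds shown here alone, how far compound 4 really lies under its limit stays open, and so does whether the loss of the aromatic ring or of the donor hydrogen matters more. Going by these compounds, it is also open whether a plain amino group, a methoxy group or a longer chain such as n-hexylamino at this position would lift inhibition clear of the scatter.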